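The compounds below may be only part of what the source reports. "The series", "measured", "known", "first", "only" and "open" are said of these compounds alone.

In a functional assay on CHO cells for antagonist activity at transient receptor potential cation channel subfamily V member 1 (Homo sapiens), read by fluorescence and calcium flux (on this read-out higher numbers stand for weaker inhibition and lower numbers for stronger inhibition), three compounds of a shared core have been measured so far. Compound 1 `O=C(N[C@H]1CCCC[C@H]1O)c1noc(-c2ccc(C(F)(F)F)cc2)c1Cl` gives 65 nM, compound 3 `O=C(N[C@H]1CC[C@H](O)CC1)c1noc(-c2ccc(C(F)(F)F)cc2)c1Cl` gives 392 nM, and compound 2 `O=C(NC1CCCC1)c1noc(-c2ccc(OC(F)(F)F)cc2)c1Br` gives 1250 nM. Compound 2 therefore stands highest of the three numbers; compound 3 is the nearest to it and compound 1 the furthest, both gaps lying beyond the scatter. For the measured compounds named here, the only step between two compounds that differ in one place is a 6.0-fold higher number from compound 1 to compound 3 (0.78 log units; beyond the scatter), and it concerns the amide side of the core, not the aromatic ring.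

Compound 4 `O=C(NC1CCCC1)c1noc(-c2ccc(Br)cc2)c1Br` differs from compound 2 by bromo in place of trifluoromethoxy on an aromatic carbon. Going by the values given here, no measured step bears on this change: compounds 1 and 3 carry trifluoromethyl on their aromatic ring, but they also differ from compound 2 in the amide part and in the halogen on the core, so their values against compound 2 cannot be attributed to the aromatic substituent alone. With nothing in the measured set speaking for a sizeable shift, compound 4 is expected to give a number close to that of compound 2, with the step of a 1.1-fold lower number from compound 2 to compound 4 (0.06 log units; within the scatter) estimated to stay within the scatter. The estimate for compound 4 is 1100 nM, with a range from 300 nM to 4000 nM.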

Compound 4, half-maximal inhibitory concentration: 410 nM
Estimate against measurement, compound 4: 2.7-fold (0.43 log units) above, and the stated range covers the measured number.
By their numbers in this assay, from the lowest: compound 1; then compounds 3 and 4 (each within the scatter of the next); then compound 2.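

In this assay, the substituent on the aromatic ring, para to a large group, proves able to move the number on its own: with the rest of the molecule unchanged, bromo in place of trifluoromethoxy gives a 3.0-fold lower number from compound 2 to compound 4 (0.48 log units; beyond the scatter). For the compounds shown here, the only earlier step, a 6.0-fold higher number from compound 1 to compound 3 (0.78 log units; beyond the scatter), lay on the amide side, so this is the first reading at the aromatic position, and here the smaller bromo, which has no hydrogen-bond acceptor, goes with the lower number than trifluoromethoxy, which has one. No measurement at hand accounts for this shift.

The compounds shown leave open how trifluoromethyl, chloro, a nitrile or a methoxy group would compare at this aromatic carbon on the same background, so a single step cannot say whether the number follows the size of the substituent or something else about it. They also leave open whether the step would keep its size with the hydroxycyclohexyl groups of compound 1 and compound 3 on the amide nitrogen, or with chloro in place of the bromo on the core.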